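The source may hold more compounds than are shown below. What is called first, only, known or untested is meant among the compounds shown, and "the series" means these compounds.

Measured so far in a functional assay on NCI-H460 cells (Homo sapiens) for cytotoxicity, read by MTT assay, with a stated time of 72 h; on this read-out lower numbers stand for stronger inhibition and higher numbers for weaker inhibition:

Compound 1, `Cc1ccc(S(=O)(=O)n2cc(COC3=C/C(=N\c4ccccc4)c4ccccc4C3=O)nn2)cc1`: 7220 nM
Compound 2, `Cc1ccc(S(=O)(=O)n2cc(COC3=C/C(=N\c4ccc(Cl)cc4)c4ccccc4C3=O)nn2)cc1`: 12100 nM

Of the compounds shown here, two have been measured, and they differ only by a chloro in place of hydrogen on an aromatic carbon. That step, a 1.7-fold higher number from compound 1 to compound 2 (0.22 log units; within the scatter), lies within the scatter, so compound 2 stands beside compound 1 rather than apart from it, and nothing in these two numbers separates them with confidence.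

Compound 3, `Cc1ccc(/N=C2\C=C(OCc3cn(S(=O)(=O)c4ccc(C)cc4)nn3)C(=O)c3ccccc32)cc1`, has not yet been measured. It differs from compound 2 by methyl in place of chloro on an aromatic carbon. Within the data shown here, no measured step bears directly on this exchange; the only step available, a 1.7-fold higher number from compound 1 to compound 2 (0.22 log units; within the scatter), concerns the arrival of the chloro group itself and was within the scatter. With so little to lean on, no shift beyond the scatter is expected in this assay in either direction. Compound 3 is therefore expected to give about 9500 nM, within a range of 4000 nM to 22000 nM. That estimate corresponds to an expected step of a 1.3-fold lower number from compound 2 to compound 3 (0.11 log units; within the scatter), which itself stays within the scatter.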

Compound 3, half-maximal inhibitory concentration: 8020 nM
Beside the measured number, compound 3's estimate is 1.2-fold (0.07 log units) above it, and the stated range covers the measured number.
By their numbers in this assay, from the lowest: compounds 1, 3 and 2 (each within the scatter of the next).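

In this assay the move from 4-chlorophenyl to 4-methylphenyl gives a 1.5-fold lower number from compound 2 to compound 3 (0.18 log units; within the scatter) and the arrival of methyl in place of hydrogen gives a 1.1-fold higher number from compound 1 to compound 3 (0.05 log units; within the scatter) in this series. Among these compounds, earlier, only chloro could be set against hydrogen on this aromatic carbon, para to a large group; with methyl added, hydrogen, chloro and methyl have all been read at this place, and no step among the three compounds leaves the scatter. Nothing in hand bears on why the three numbers lie so close together.

On these data alone, all three groups are small and carry no charge, so it remains open whether an amine, a carboxylic acid or a longer chain such as butyl at this same place would move the number beyond the scatter. It is equally open whether the closeness of hydrogen, chloro and methyl would hold on other cell lines, since these compounds are shown against only one.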